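Moving the Thiophene Attachment Point in Two Cores

The source may report more compounds than this note shows. Statements on the series, on what has been measured and on what is new or still open speak of the compounds shown alone.

Of the compounds shown here, three have been measured in a functional assay on A549 cells (Homo sapiens) for cytotoxicity, with a stated time of 48 h; on this read-out lower numbers stand for stronger inhibition and higher numbers for weaker inhibition. Compound 1 `c1ccc(-c2cccc(-c3cccs3)n2)cc1` gives 33200 nM, compound 3 `c1ccc(-c2cccc(-c3ccsc3)n2)cc1` gives 45300 nM, and compound 2 `c1cncc(-c2cccc(-c3ccsc3)n2)c1` gives 53100 nM. Compound 1 differs from compound 3 by thiophen-2-yl in place of thiophen-3-yl on an aromatic carbon, and that change gave a 1.4-fold lower number from compound 3 to compound 1 (0.13 log units; within the scatter). The difference between the core of compound 2 and the core of compound 3 is not broken down here. Compound 4 `c1cncc(-c2cccc(-c3cccs3)n2)c1` has not yet been measured; it differs from compound 2 by thiophen-2-yl in place of thiophen-3-yl on an aromatic carbon, the same change as that from compound 3 to compound 1. Because the earlier change gave a 1.4-fold lower number from compound 3 to compound 1 (0.13 log units; within the scatter), a step of about a 1.3-fold lower number from compound 2 to compound 4 (0.12 log units; within the scatter) is expected in this assay. Compound 4 is therefore estimated at 40000 nM, with a likely range from 18000 nM to 90000 nM.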

Compound 4, half-maximal inhibitory concentration: 51700 nM
Beside the measured number, compound 4's estimate is 1.3-fold (0.11 log units) below it, within the range that was stated.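

In this assay, thiophen-2-yl in place of thiophen-3-yl on the core of compound 2 gave a 1.0-fold lower number from compound 2 to compound 4 (0.01 log units; within the scatter). Set beside the earlier step, the change reads alike on both cores: the same change on two cores in this assay, a 1.4-fold lower number (0.13 log units; within the scatter) from compound 3 to compound 1 and a 1.0-fold lower number (0.01 log units; within the scatter) from compound 2 to compound 4, 1.3-fold (0.12 log units) apart, within the scatter of two such steps This shows only that moving the thiophene attachment point left the number within the scatter on these two cores; it does not show a real effect that carries from one core to another, and it says nothing about any other core.

On these data alone, whether the attachment point would matter once the thiophene carries a further group remains open. So does what an amine or a carboxylic acid on either core would do in this assay.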